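Lengthening the Amine Chain on a Second Core

This account rests on a few compounds, and the source may have more. Where it says the series, first, only, none or still open, it means among the compounds named here.

Compound 1 `CCCCCCCCCCc1ccc(-c2noc(CCCN)n2)cc1` carries a 3-aminopropyl group on its five-membered ring. In an assay on HeLa cells for inhibition of sphingosine-1-phosphate transporter SPNS2 (Mus musculus), read by LC-MS, tested at 2 uM (on this read-out higher numbers stand for more inhibition at the one concentration tested (going by the name of the read-out) and lower numbers for less inhibition), compound 1 gives 67%. Compound 2 `CCCCCCCCCCc1ccc(-c2noc(CCCCN)n2)cc1` differs from it by aminomethyl in place of amino on a saturated chain carbon, three bonds along the chain from an aromatic carbon, and this change gave a number 12 percentage points lower from compound 1 to compound 2 (beyond the scatter). Compound 3 `CCCCCCCCCCc1ccc(-c2noc([C@@H](N)CCCN)n2)cc1` has a different core, in that (1,4-diaminobutyl in place of 3-aminopropyl on an aromatic carbon). In this assay compound 2 gives 55%, and compound 3 gives 40%. Compound 3 is the lowest of the three, with a number 15 percentage points lower from compound 2 to compound 3 (beyond the scatter) and a number 27 percentage points lower from compound 1 to compound 3 (beyond the scatter).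

Compound 4 `CCCCCCCCCCc1ccc(-c2noc([C@@H](N)CCCCN)n2)cc1` is not yet measured. It differs from compound 3 by aminomethyl in place of amino on a saturated chain carbon, four bonds along the chain from an amine nitrogen and an aromatic carbon. This is the same kind of change as that from compound 1 to compound 2, not the same: in compound 1 the amino sits three bonds along the chain from an aromatic carbon, whereas in compound 3 it sits four bonds along the chain from an amine nitrogen and an aromatic carbon. The earlier change gave a number 12 percentage points lower from compound 1 to compound 2 (beyond the scatter), and on that single step the expectation for compound 4 is a number 12 percentage points lower from compound 3 to compound 4 (beyond the scatter). Compound 4 is therefore estimated to give 28% in this assay, most likely between 14% and 42%.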

Compound 4, a percentage reported as inhibition, at one concentration (the size of the read-out at that concentration, not a potency): 43%
For compound 4 the middle estimate is 15 percentage points below the measured one; the whole stated range lies below it.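

Lengthening the chain did not carry over from one core to the other in this assay: the same change on two cores in this assay, a number 12 percentage points lower (beyond the scatter) from compound 1 to compound 2 and a number 3 percentage points higher (within the scatter) from compound 3 to compound 4, 15 percentage points apart, beyond the scatter of two such steps

On the core of compound 3, the added carbon gave a number 3 percentage points higher from compound 3 to compound 4 (within the scatter), so the loss seen on the core of compound 1 cannot be assumed to appear on this second core. This rests on a single pair of compounds per core: it shows that the outcome of this change depended on the core here, but not why, and it gives no general rule for other chain lengths. Compound 4, which keeps the extra amino group on the chain carbon bound to the aromatic carbon, still sits clearly lower than the two compounds without that group, with a number 12 percentage points lower from compound 2 to compound 4 (beyond the scatter) and a number 24 percentage points lower from compound 1 to compound 4 (beyond the scatter).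

The compounds shown leave open how either core would respond to a still longer chain, or to a carboxylic acid in place of the amine. They also leave open how these single-concentration percentages would translate into potency.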